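Series notes: hydroxy replaced by methyl on the fused ring

The source may hold more compounds than are shown below. What is called first, only, known or untested is meant among the compounds shown, and "the series" means these compounds.

Measured in an assay for binding affinity to 17-beta-hydroxysteroid dehydrogenase 14 (Homo sapiens), read by fluorescence, with a stated time of 15 min, in the presence of a further agent that is not named here; on this read-out lower numbers stand for stronger inhibition and higher numbers for weaker inhibition:
- compound 1 `O=C(Nc1ccc(F)c(O)c1)c1cccc(-c2cccc(O)c2F)n1`: 336 nM
- compound 2 `O=C(c1ccc(F)c(O)c1)c1ccc2cc(O)ccc2n1`: 119 nM
- compound 3 `C=C(c1ccc(F)c(O)c1)c1cccc(-c2cccc(O)c2F)n1`: 1.5 nM

Compound 2 stands second highest of the three numbers in this assay. Compound 1 gives the nearest number, above that of compound 2 and beyond the scatter; compound 3 gives the furthest, far below it and well beyond the scatter. Among the compounds with values here, none of the three measured pairs differ in a single place, so no step among them bears directly on the change now in question.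

Compound 4 `Cc1ccc2nc(C(=O)c3ccc(F)c(O)c3)ccc2c1` is the next candidate. It differs from compound 2 in one place: methyl in place of hydroxy on an aromatic carbon. The measured compounds all carry a hydroxy on each of the two outer rings, so nothing among them shows what losing one does. The step from compound 2 to compound 4 is expected to move toward weaker inhibition, by a 3.4-fold higher number from compound 2 to compound 4 (0.53 log units; beyond the scatter), a change larger than the scatter. For compound 4 the estimate in this assay is 400 nM, in a range from 100 nM to 1600 nM.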

Compound 4, inhibition constant in the 17-beta-hydroxysteroid dehydrogenase 14 assay: 6 nM
For compound 4 the middle estimate is 67-fold (1.82 log units) above the measured one; measured number outside the range, below it.
By their numbers in the 17-beta-hydroxysteroid dehydrogenase 14 assay, from the lowest: compound 3; then compound 4; then compound 2; then compound 1.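

Within the data shown here, in the 17-beta-hydroxysteroid dehydrogenase 14 assay the hydroxy on the fused ring proves dispensable: methyl in its place, on the aromatic carbon meta to a fused ring and para to a fused ring, gives a 20-fold lower number from compound 2 to compound 4 (1.30 log units; beyond the scatter), a gain that the earlier compounds, all with a hydroxy on each outer ring, could not show. In a physicochemical assay for solubility, in phosphate buffer, with a stated time of 24 h, at pH 7.4, tested at 200 uM (a lower number here means a less soluble compound, a higher number a more soluble compound), the same change comes with an at least 8.0-fold lower number from compound 2 to compound 4 (0.90 log units; beyond the scatter), a step read against a limit: the limit of > 200000 nM in the physicochemical assay, at which 1 of the 2 values shown sits. In the physicochemical assay the value of compound 2, > 200000 nM, is a limit of the assay and not a number. In the physicochemical assay compound 4 gives 25000 nM as a measured number.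

On these data alone, whether the gain comes from methyl itself or from the absence of hydroxy stays open; an amine or a methoxy group on this carbon would separate the two. Also open, as far as these compounds go, is whether the same change carries over to the core of compound 3.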